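This account rests on a few compounds, and the source may have more. Where it says the series, first, only, none or still open, it means among the compounds named here.

Measured compounds:
compound 1, `O=C(N/N=C/c1ccco1)c1cccc(S(=O)(=O)N2CCOCC2)c1`: > 100000 nM
compound 2, `O=C(N/N=C/c1ccccc1O)c1cccc(S(=O)(=O)N2CCOCC2)c1`: 13800 nM
compound 3, `O=C(N/N=C/c1cc(Cl)ccc1O)c1cccc(S(=O)(=O)N2CCOCC2)c1`: 10500 nM

Compound 3 stands lowest of the two numbers shown in a functional assay on PC-3 cells (Homo sapiens) for antiproliferative activity, read by MTT assay, with a stated time of 72 h (a higher number here means a weaker inhibitor, a lower number a stronger inhibitor), with compound 2 the nearest at a gap within the scatter, as a 1.3-fold lower number from compound 2 to compound 3 (0.12 log units; within the scatter) shows. For compound 1 the result is a limit of this assay and not a number (the limit of > 100000 nM in this assay, at which 1 of the 3 values shown sits). The steps from compound 1 to the two phenol-bearing compounds were large: an at least 7.2-fold lower number from compound 1 to compound 2 (0.86 log units; beyond the scatter) and an at least 9.5-fold lower number from compound 1 to compound 3 (0.97 log units; beyond the scatter).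

Compound 4, `O=C(N/N=C/c1cc(Br)cc(Br)c1O)c1cccc(S(=O)(=O)N2CCOCC2)c1`, differs from compound 3 in one place: 3,5-dibromo-2-hydroxyphenyl in place of 5-chloro-2-hydroxyphenyl on a carbon with a double bond to nitrogen. The step that bears on it most directly is the addition of a halogen to the 2-hydroxyphenyl ring, a 1.3-fold lower number from compound 2 to compound 3 (0.12 log units; within the scatter), which stayed within the scatter. Compound 4 carries two bromines on that ring in place of one chlorine, and the shared phenol is kept. In this assay compound 4 is therefore expected to sit close to compound 3, with at most a small step downward, a 1.3-fold lower number from compound 3 to compound 4 (0.12 log units; within the scatter). The estimate for compound 4 is 8000 nM, with a range from 3000 nM to 25000 nM.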

Compound 4, half-maximal inhibitory concentration: 9700 nM
Compound 4: the middle estimate sits 1.2-fold (0.08 log units) below what was measured, within the range that was stated.
By their numbers in this assay, from the lowest: compounds 4, 3 and 2 (each within the scatter of the next). At a limit, above all of these: compound 1.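

In this assay the two bromines of 3,5-dibromo-2-hydroxyphenyl, set against the single chlorine of 5-chloro-2-hydroxyphenyl, leave the result within the scatter (a 1.1-fold lower number from compound 3 to compound 4 (0.03 log units; within the scatter)), and the same holds against plain 2-hydroxyphenyl (a 1.4-fold lower number from compound 2 to compound 4 (0.15 log units; within the scatter)). For the compounds shown here, at this place, then, compounds 2, 3 and 4 do not separate whether the ring carries no halogen, one chlorine or two bromines, and only the step from furan-2-yl is beyond the scatter (an at least 10-fold lower number from compound 1 to compound 4 (1.01 log units; beyond the scatter)). That step has a limit at one end, and compound 1 has a limit of the assay and not a number: the limit of > 100000 nM in this assay, at which 1 of the 4 values shown sits.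

The compounds shown leave open whether a plain phenyl, or a phenyl with a methoxy group or an amine in place of the hydroxyl, would keep these values. The hydroxyl's share in the step from furan-2-yl therefore cannot be told apart from that of the ring.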